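A few compounds are considered here, and "the series" means these few. Any claim that something is new, unique, unknown or untested is made for them only; others in the source may bear on it.

Compound 1 `CC(=O)OCc1ccc2oc(=O)c(C(=O)Sc3cccc(Cl)c3)cc2c1` gives 65.8% in a functional assay on HT-1080 cells (Homo sapiens), read by transwell migration, with a stated time of 24 h, tested at 1 uM; on this read-out higher numbers stand for a weaker effect at the one concentration tested and lower numbers for a stronger effect.
Compound 2 `CC(=O)OCc1ccc2oc(=O)c(C(=O)N(C)c3ccccc3Cl)cc2c1` gives 62.8% in this assay.

Among the measured compounds shown here, compound 2 stands within the scatter of compound 1, the only other measured compound, as the step of a number 3 percentage points lower from compound 1 to compound 2 (within the scatter) shows. Compound 3 `CC(=O)OCc1ccc2oc(=O)c(C(=O)N(C)c3cccc(Cl)c3)cc2c1` differs from compound 2 only in the ring on the amide-type nitrogen: 3-chlorophenyl in place of 2-chlorophenyl on an amide-type nitrogen. For the measured compounds named here, no measured step changes that ring alone; the one step known, a number 3 percentage points lower from compound 1 to compound 2 (within the scatter), altered more than the ring and stayed within the scatter. No step beyond the scatter is therefore expected in this assay for compound 3, and its value is estimated at 63%, between 50% and 76%, a step of a number 0.2 percentage points higher from compound 2 to compound 3 (within the scatter).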

Compound 3, a percentage reported as activity, at one concentration (the size of the read-out at that concentration, not a potency): 82.6%
Beside the measured number, compound 3's estimate is 19.6 percentage points below it, outside the stated range (above it).
By their numbers in this assay, from the lowest: compounds 2 and 1 (each within the scatter of the next); then compound 3.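

In this assay, the place of the chlorine on the ring matters: 3-chlorophenyl in place of 2-chlorophenyl on an amide-type nitrogen weakens the effect (a number 19.8 percentage points higher from compound 2 to compound 3 (beyond the scatter)), although both groups hold the same atoms. With 3-chlorophenyl kept, swapping the sulfanyl link to the carbonyl carbon for a methyl-bearing amino link also weakens it (a number 16.8 percentage points higher from compound 1 to compound 3 (beyond the scatter)), so this link counts too. No measurement shown explains either step. Still open, going by these compounds, is how a plain phenyl ring, or bromine in place of chlorine, would read here.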